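The source may hold more compounds than are shown below. What is called first, only, known or untested is meant among the compounds shown, and "the series" means these compounds.

Compound 1 `Cc1ccc(S(=O)(=O)Oc2ccccc2/C=C(\C#N)C(=O)Nc2nnc(C)s2)cc1`: 33%
Compound 2 `COc1ccc(Cc2nnc(NC(=O)/C(C#N)=C/c3ccccc3OS(=O)(=O)c3ccc(F)cc3)s2)cc1`: 80%
Compound 3 `N#C/C(=C\c1ccccc1OS(=O)(=O)c1ccc(Cl)cc1)C(=O)Nc1nnc(Cc2ccccc2)s1`: 73%

In a functional assay on RS4-11 cells (Homo sapiens) for inhibition, read by CCK-8 assay, with a stated time of 48 h, tested at 20 uM (a higher number here means more inhibition of growth at the concentration tested, a lower number less inhibition of growth), compound 1 stands lowest of the three at 33%, beyond the scatter from both others. Compound 4 `Cc1ccc(S(=O)(=O)Oc2ccccc2/C=C(\C#N)C(=O)Nc2nnc(Cc3ccc(Cl)cc3)s2)cc1` has not yet been measured. It carries 4-chlorophenyl in place of hydrogen on a saturated chain carbon bound to an aromatic carbon. For the measured compounds named here, no measured pair differs by this change alone. Compound 3 also bears an aromatic ring on that chain carbon and gives 73%, and compound 2, likewise, gives 80%, though both differ from compound 1 elsewhere too. An upward step beyond the scatter is therefore expected, estimated as a number 39 percentage points higher from compound 1 to compound 4 (beyond the scatter). For compound 4 the estimated value is 72%, with an expected range of 52% to 90%.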

Compound 4, percent growth inhibition at one concentration: 69%
Compound 4: the middle estimate sits 3 percentage points above what was measured; low and high end bracket the measured number.
By their numbers in this assay, from the lowest: compound 1; then compounds 4, 3 and 2 (each within the scatter of the next, the first and the last beyond it).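

In this assay, the change from methyl to 4-chlorobenzyl gives a number 36 percentage points higher from compound 1 to compound 4 (beyond the scatter), with the rest of the structure unchanged. Earlier, an aromatic ring on this saturated chain carbon appeared only alongside other differences, whereas this pair ties a large rise to this one position. Nothing available explains the rise. The compounds shown leave open how a longer chain such as 2-phenylethyl would read at this position. They also leave open how an amine in place of the chlorine would read in this assay.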